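The compounds below may be only part of what the source reports. "The series", "measured", "known", "first", "only" and "open" are said of these compounds alone.

Compound 2 `CCOc1ccc(N/N=C2\CCC(C)n3c2ncc(C(=O)O)c3=O)cc1` was examined in a functional assay on the whole organism for inhibition, with Rattus norvegicus as the target; on this read-out higher numbers stand for an effect only at larger amounts of compound and lower numbers for an effect already at smaller amounts. In this assay compound 2 gives only a limit, > 100 umol/kg, so where it truly stands is not known beyond that bound. The related compound 1 `CC1CC/C(=N\Nc2ccc(Br)cc2)c2ncc(C(=O)O)c(=O)n21` also gives only a limit in this assay, > 1000 umol/kg. For the measured compounds named here, the one measured step, a step that the two limits leave unreadable from compound 1 to compound 2, can therefore not be read in size or direction, since one value sits at the limit of > 100 umol/kg in this assay, at which 1 of the 2 values shown sits, and the other at the limit of > 1000 umol/kg in this assay, at which 1 of the 2 values shown sits.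

Compound 3 `CC1CC/C(=N\Nc2ccc([N+](=O)[O-])cc2)c2ncc(C(=O)O)c(=O)n21` has not yet been measured. It differs from compound 2 in one place: nitro in place of ethoxy on an aromatic carbon. Going by the values given here, none of the measured steps bears on this exchange, and the single step that exists is itself unreadable, so no size and no direction can be drawn from it for this assay. Compound 3 is expected in this assay at 300 umol/kg, with a range from 100 umol/kg to 1000 umol/kg. The step expected, a step that the limit leaves unreadable from compound 2 to compound 3, is set against a limit and is estimated only loosely, with a real chance that the assay again reports a limit and no number.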

Compound 3, dose for 50% inhibition: > 320 umol/kg
Compound 3 ended at the assay's limit (the forecaster's own chance of this, stated with the estimate: 60%); at least 1.0-fold (0.02 log units) between middle value and limit.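

Compound 3 also gives only a limit in this assay, > 320 umol/kg. None of the steps among compound 1, compound 2 and compound 3 can be read in size or direction. The compounds shown leave open where each of the three truly stands in this assay, and whether exchanging bromo, ethoxy and nitro on the aromatic carbon changes the result at all.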